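A Methoxy Swap at the Assay Limit

A few compounds are considered here, and "the series" means these few. Any claim that something is new, unique, unknown or untested is made for them only; others in the source may bear on it.

Values in an ADME assay on NCI-H226 cells (Homo sapiens) for cytotoxicity, read by MTT assay; a lower number here means a stronger inhibitor, a higher number a weaker inhibitor:
- compound 1 `O/N=C(\COc1cccc2ccccc12)c1ccccc1`: 47100 nM
- compound 2 `O/N=C(\COc1cccc2ccccc12)c1ccc(F)cc1`: > 50000 nM (a limit)
- compound 3 `O/N=C(\COc1cccc2ccccc12)c1ccc(Br)cc1`: > 50000 nM (a limit)

Compound 3 stands at > 50000 nM, which is a limit and not a number. Compound 3 thus shares (the limit of > 50000 nM in this assay, at which 2 of the 3 values shown sit). Compound 4 `COc1ccc(/C(COc2cccc3ccccc23)=N/O)cc1` carries methoxy in place of bromo on an aromatic carbon, para to a large group (methoxy in place of bromo on an aromatic carbon). Among the compounds with values here, three measured steps bear on this change: an at least 1.0-fold higher number from compound 1 to compound 2 (0.02 log units; that floor lies within the scatter), an at least 1.0-fold higher number from compound 1 to compound 3 (0.02 log units; that floor lies within the scatter) and a step that the two limits leave unreadable from compound 2 to compound 3. None of them shows a change beyond the scatter, so no step beyond the scatter is expected in this assay. The expected step is a number no higher from compound 3 to compound 4 (the limit leaves the size open). Compound 4 is expected at 50000 nM, with an estimated range of 25000 nM to 100000 nM.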

Compound 4, half-maximal inhibitory concentration: 36700 nM
Compound 4: middle estimate off by 1.4-fold (0.13 log units), on the high side; measured number inside the range.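

In this assay methoxy gives a readable number where fluoro and bromo gave only limits, yet the readings of an at least 1.3-fold lower number from compound 3 to compound 4 (0.13 log units; that floor lies within the scatter) and an at least 1.3-fold lower number from compound 2 to compound 4 (0.13 log units; that floor lies within the scatter) are floors and not sizes. Set against hydrogen, methoxy gives a 1.3-fold lower number from compound 1 to compound 4 (0.11 log units; within the scatter) and so no change that can be told from the scatter. The floors stay floors because the fluoro and bromo compounds sit at a limit: the limit of > 50000 nM in this assay, at which 2 of the 4 values shown sit.

The compounds shown leave open whether an amine or a carboxylic acid at this place would give a step beyond the scatter.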